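The source may hold more compounds than are shown below. What is called first, only, known or untested is meant among the compounds shown, and "the series" means these compounds.

Measured compounds:
- compound 1 `COc1ccc(CNc2nc([Se]C)nc3ccccc23)cc1`: 33000 nM
- compound 2 `CCCCC[Se]c1nc([Se]CCCCC)c2cccnc2n1`: 15200 nM

Both numbers come from a functional assay on HTB-54 cells (Homo sapiens) for cytotoxicity, read by MTT assay, with a stated time of 72 h; on this read-out lower numbers stand for stronger inhibition of growth and higher numbers for weaker inhibition of growth. Of the two, compound 1 gives the higher number, so the weaker growth inhibition, and the gap to compound 2 lies beyond the usual scatter of this assay. Among the compounds with values here, no pair of measured compounds differs in a single place, so no measured step is available to anchor the change considered next.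

Compound 3 `COc1ccc(CNc2nc([SeH])nc3ccccc23)cc1` is derived from compound 1 by the change (hydrogen in place of methyl on a selenium), that is, hydrogen in place of methyl on a selenium. The rest of the core of compound 1, including the substituted benzylamine, is unchanged. Within the data shown here, the data give no measured step for removal of a methyl from a selenium, and compound 2 carries two pentyl selenides on a different core, so it offers no direct comparison. In this assay the step from compound 1 to compound 3 is therefore expected to be small, a 1.1-fold lower number from compound 1 to compound 3 (0.04 log units; within the scatter), with no clear direction beyond the scatter. For compound 3 the value in this assay is estimated at 30000 nM, with a plausible range from 10000 nM to 90000 nM.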

Compound 3, concentration for 50% growth inhibition: 7110 nM
Compound 3: middle estimate off by 4.2-fold (0.63 log units), on the high side; measured number below the stated range.
By their numbers in this assay, from the lowest: compound 3; then compound 2; then compound 1.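

In this assay, within the data shown here, what sits on the selenium of the core of compound 1 proves to matter: a 4.6-fold lower number from compound 1 to compound 3 (0.67 log units; beyond the scatter) is the first single-place step, and it lies beyond the usual scatter. Hydrogen in place of methyl on a selenium removes a single carbon and leaves the substituted benzylamine untouched, yet it gives stronger growth inhibition, so this position responds even to the smallest change on the selenium. Nothing at hand gives a reason for this step, which remains a single observation on one core.

Left open is whether an ethyl or a longer chain on this selenium would give a number nearer to that of the methyl or the hydrogen, and whether an amine or a carboxylic acid at the end of such a chain would shift it further. Also open, as far as these compounds go, are whether hydrogen on a selenium gives a step of similar size on the different core of compound 2, and whether sulfur in place of the selenium would hold the value of compound 3 at 7110 nM.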